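Chloro in Place of Hydrogen: Cytotoxicity Outlook

A few compounds are considered here, and "the series" means these few. Any claim that something is new, unique, unknown or untested is made for them only; others in the source may bear on it.

Compound 1 `COc1ccccc1S(=O)(=O)/C=C/c1cccnc1` and compound 3 `COc1cccc(S(=O)(=O)/C=C/c2cccnc2)c1` are built from the same atoms joined differently; the difference between the two cores is not broken down here. In an ADME assay on BV-2 cells (Mus musculus) for cytotoxicity, with a stated time of 24 h, tested at 10 uM (on this read-out higher numbers stand for a weaker effect at the one concentration tested and lower numbers for a stronger effect), compound 1 gives 100% and compound 3 gives 100%, so the two stand level at the digits reported. Compound 2 `COc1ccccc1S(=O)(=O)/C=C/c1cccnc1Cl` differs from compound 1 by chloro in place of hydrogen on an aromatic carbon. In this assay compound 2 gives 99.7%, and the step of a number 0.3 percentage points lower from compound 1 to compound 2 (within the scatter) leaves the read-out essentially untouched.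

Compound 4 `COc1cccc(S(=O)(=O)/C=C/c2cccnc2Cl)c1` has not yet been measured. It differs from compound 3 by chloro in place of hydrogen on an aromatic carbon, which is the same change as that from compound 1 to compound 2, made at the same kind of position on the other core. Because a number 0.3 percentage points lower from compound 1 to compound 2 (within the scatter) stayed within the scatter, the expected step is a number 0.5 percentage points lower from compound 3 to compound 4 (within the scatter), also within the scatter. The estimated read-out for compound 4 in this assay is 99.5%, expected to fall between 92% and 104%.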

Compound 4, a percentage reported as activity, at one concentration (the size of the read-out at that concentration, not a potency): 100%
The estimate for compound 4 lay 0.5 percentage points below the measured number; the range from low to high includes it.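

In this assay, chloro in place of hydrogen on an aromatic carbon gives no change at the digits printed from compound 3 to compound 4 (within the scatter), and the change reads the same on both cores: the same change on two cores in this assay, a number 0.3 percentage points lower (within the scatter) from compound 1 to compound 2 and no change at the digits printed (within the scatter) from compound 3 to compound 4, 0.3 percentage points apart, within the scatter of two such steps. Within these two pairs, then, placing a chloro next to the ring nitrogen carries from one core to the other without a visible shift in the read-out. This is agreement between two steps that barely register, so it does not show how the same change would behave in a compound with a stronger effect in this assay, and two pairs do not make a rule for the whole series.

The compounds shown leave open whether a different group at that place, such as a methyl, an amine or a carboxylic acid, would also leave the read-out where it stands. They also leave open what a chloro would do elsewhere on the ring, and how these compounds behave at any other concentration or exposure time.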